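Shortening a hydroxamic chain that already sits at the limit

The source may report more compounds than this note shows. Statements on the series, on what has been measured and on what is new or still open speak of the compounds shown alone.

Compound 1 `CNC(=O)CCCCCCCn1nc(-c2cnc3[nH]ccc3c2)c2c(N)ncnc21` value 51000 nM
Compound 2 `Nc1ncnc2c1c(-c1cnc3[nH]ccc3c1)nn2CCCCC(=O)NO` value > 150000 nM (a limit)
Compound 3 `Nc1ncnc2c1c(-c1cnc3[nH]ccc3c1)nn2CCCCCCCCCC(=O)NO` value 6550 nM

All three were tested in a functional assay on A549 cells (Homo sapiens) for inhibition, read by MTT assay, with a stated time of 72 h (a higher number here means a weaker inhibitor, a lower number a stronger inhibitor), on the same shared core. Compound 2 stands at > 150000 nM and this is a limit of the assay, not a number (the limit of > 150000 nM in this assay, at which 1 of the 3 values shown sits).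

Compound 4 `Nc1ncnc2c1c(-c1cnc3[nH]ccc3c1)nn2CCC(=O)NO` has not yet been measured. Its difference from compound 2 is hydroxycarbamoyl in place of 2-(hydroxycarbamoyl)ethyl on a saturated chain carbon, two bonds along the chain from an aromatic nitrogen. The chain therefore gets shorter.

The closest guide is an at least 22-fold lower number from compound 2 to compound 3 (1.35 log units; beyond the scatter), a large step in which the chain grows longer. The two steps with the methylcarbamoyl end, an at least 2.9-fold higher number from compound 1 to compound 2 (0.46 log units; beyond the scatter) and a 7.8-fold lower number from compound 1 to compound 3 (0.89 log units; beyond the scatter), are smaller, and they change the chain end and its length together, so they say less. With only two hydroxycarbamoyl chains measured, the trend is thin, but it points to a weaker compound, not a stronger one, in this assay as the chain shortens.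

The expected change is small and upward, and the estimated step is a step that the limit leaves unreadable from compound 2 to compound 4, though another limit is the likelier report. For compound 4 the estimated value is 180000 nM, with an expected range from 80000 nM to 400000 nM.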

Compound 4, half-maximal inhibitory concentration: > 150000 nM
Compound 4 gave a limit, no number; the forecaster's own chance of this, stated with the estimate: 70%; the middle value lies beyond the limit too.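

Compound 4 gives > 150000 nM in this assay, which is a limit of the assay and not a number. The step from compound 2 cannot be read, so cutting 4-(hydroxycarbamoyl)butyl back to 2-(hydroxycarbamoyl)ethyl shows no measurable change, and the two shortest hydroxycarbamoyl chains shown can't be ranked against each other: the limit of > 150000 nM in this assay, at which 2 of the 4 values shown sit. The one readable new comparison is an at least 2.9-fold higher number from compound 1 to compound 4 (0.46 log units; beyond the scatter), which places this short chain on the same side of the methylcarbamoyl compound as the other short chain, whereas the longest hydroxycarbamoyl chain, in compound 3, gives a real number of 6550 nM.

Open, from the compounds shown here alone, is the chain length at which a measurable value first appears, since a chain of intermediate length would show where the readings begin, and an even longer chain would show whether the gain continues past compound 3. Also open, going by these compounds, is how a carboxylic acid or an amine in place of the hydroxycarbamoyl end would read in this assay, at either short or long chain length.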